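This account rests on a few compounds, and the source may have more. Where it says the series, first, only, none or still open, it means among the compounds named here.

In a functional assay on K562 cells (Homo sapiens) for antiproliferative activity, read by MTT assay, with a stated time of 48 h (on this read-out lower numbers stand for stronger inhibition and higher numbers for weaker inhibition), the measured compounds give
Compound 1 `COc1ccc(-c2ccc3c(c2)C(=O)C(=O)N3Cc2ccc(F)cc2)cc1` gives 560 nM
Compound 2 `COc1ccc(-c2ccc3c(c2)C(=O)C(=O)N3Cc2ccc(Cl)cc2)cc1` gives 350 nM
Compound 3 `COc1ccc(-c2ccc3c(c2)C(=O)C(=O)N3Cc2ccccc2Cl)cc1` gives 380 nM

Compound 1 lies within the scatter of both other compounds, so the three values cannot be ranked. Compound 4 `COc1ccc(-c2ccc3c(c2)C(=O)C(=O)N3Cc2cccc(OC)c2)cc1`, not yet measured, keeps the core of compound 1 and differs only in the benzyl group (3-methoxyphenyl in place of 4-fluorophenyl on a saturated chain carbon bound to an amide-type nitrogen in a ring). In words, 3-methoxyphenyl stands in place of 4-fluorophenyl on a saturated chain carbon bound to an amide-type nitrogen in a ring. The nearest evidence comes from measured changes at that same place. Chloro in place of fluoro gave a small step (a 1.6-fold lower number from compound 1 to compound 2 (0.20 log units; within the scatter)). Moving to 2-chlorophenyl gave similar small steps (a 1.5-fold lower number from compound 1 to compound 3 (0.17 log units; within the scatter); a 1.1-fold higher number from compound 2 to compound 3 (0.04 log units; within the scatter)). None of these compounds carries 3-methoxyphenyl, so the evidence for this change is indirect. No step beyond the scatter is therefore expected in this assay, and no firm direction can be given. The expected step is small (a 1.4-fold lower number from compound 1 to compound 4 (0.15 log units; within the scatter)). For compound 4 the estimated value is 400 nM (expected range from 150 nM to 1000 nM).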

Compound 4, half-maximal inhibitory concentration: 680 nM
Compound 4: the middle estimate sits 1.7-fold (0.23 log units) below what was measured; measured number inside the range.
By their numbers in this assay, from the lowest: compounds 2, 3, 1 and 4 (each within the scatter of the next).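

In this assay the step to 3-methoxyphenyl, a group with no halogen and with a hydrogen-bond acceptor that 4-fluorophenyl lacks, stays within the scatter (a 1.2-fold higher number from compound 1 to compound 4 (0.08 log units; within the scatter)). The steps from the two chlorinated compounds also stay within it (a 1.8-fold higher number from compound 3 to compound 4 (0.25 log units; within the scatter); a 1.9-fold higher number from compound 2 to compound 4 (0.29 log units; within the scatter)), so the four compounds cannot be ranked, and this position now shows no clear difference between fluoro, chloro and methoxy benzyl groups in this assay. No measurement is available to explain these small steps.

Still open, as far as these compounds go, is whether 2-methoxyphenyl or 4-methoxyphenyl would read the same as 3-methoxyphenyl. From the compounds shown here alone, it is also open whether a more different group here, such as a phenyl ring carrying an amine or a carboxylic acid, or a longer chain to the amide-type nitrogen, would give a step beyond the scatter.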